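Benzyl substituent swap on the shared core, cytotoxicity

This account rests on a few compounds, and the source may have more. Where it says the series, first, only, none or still open, it means among the compounds named here.

Compound 1 `N#Cc1ccc(Cn2cc(COc3ccc4c(=O)ccoc4c3)nn2)cc1` carries a 4-cyanobenzyl group on the shared core. In a functional assay on A549 cells (Homo sapiens) for cytotoxicity, read by MTT assay, with a stated time of 48 h (a higher number here means a weaker inhibitor, a lower number a stronger inhibitor), compound 1 gives > 100000 nM, which is a limit of the assay and not a number. Compound 1 thus stands at the limit of > 100000 nM in this assay, at which 2 of the 3 values shown sit, and only a limit is known for it. Compound 2 `O=c1ccoc2cc(OCc3cn(Cc4ccccc4Cl)nn3)ccc12` also rests at a limit: in this assay compound 2 gives > 100000 nM. Going by the values given here, compound 3 `O=c1ccoc2cc(OCc3cn(Cc4cccc([N+](=O)[O-])c4)nn3)ccc12` is the one compound with a number, giving 9450 nM in this assay.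

The measured steps are a step that the two limits leave unreadable from compound 1 to compound 2, an at least 10-fold lower number from compound 1 to compound 3 (1.02 log units; beyond the scatter) and an at least 10-fold lower number from compound 2 to compound 3 (1.02 log units; beyond the scatter). Both readable steps replace the whole aryl group by 3-nitrophenyl, not a single substituent at one place.

Compound 4 `O=c1ccoc2cc(OCc3cn(Cc4ccc(Br)cc4)nn3)ccc12` differs from compound 1 by bromo in place of cyano on an aromatic carbon. Among the compounds with values here, no measured step changes only this substituent, so none bears directly on it; the two readable steps show that a different aryl group can pull the number down by a large step, but the move from 4-cyanophenyl to 4-bromophenyl is smaller in kind. The expectation is that compound 4 stays near the limit, with an estimated step of a number no higher from compound 1 to compound 4 (the limit leaves the size open). Compound 4 is estimated at 100000 nM, within 20000 nM to 500000 nM.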

Compound 4, half-maximal inhibitory concentration: > 100000 nM
Compound 4: no number, only a limit; the forecaster's own chance of this, stated with the estimate: 65%; the middle value sits exactly at the limit.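

Compound 4 also rests at a limit of the assay and not at a number in this assay, so bromo in place of cyano on an aromatic carbon, para to a large group, brings no drop into view: the limit of > 100000 nM in this assay, at which 3 of the 4 values shown sit. The steps to compound 4 from compound 1 and from compound 2 join limit to limit and cannot be read. Going by these compounds alone, the one readable new step is an at least 10-fold higher number from compound 3 to compound 4 (1.02 log units; beyond the scatter), which places 4-bromophenyl with 4-cyanophenyl and 2-chlorophenyl on the far side of that gap, and compound 3 remains the only one of the four compounds with a number.

Open, on these data alone, is whether the number of compound 3 goes with the nitro group itself or with its place on the ring, a question that a 4-nitrobenzyl or a 3-bromobenzyl compound on the shared core would separate. Also open, as far as these compounds go, are how far the three compounds at the limit lie beyond it and how an amine or a carboxylic acid on the benzyl ring would read in this assay.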